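This account rests on a few compounds, and the source may have more. Where it says the series, first, only, none or still open, it means among the compounds named here.

Of the compounds shown here, three have been tested so far in a functional assay on HepG2 cells (Homo sapiens) for cytotoxicity, read by MTT assay, with a stated time of 48 h; on this read-out lower numbers stand for stronger inhibition and higher numbers for weaker inhibition. Compound 1, with the structure `CC1=NN(S(=O)(=O)c2ccc(C)cc2)C(c2cc(Br)ccc2O)C1`, gives 20800 nM. Compound 2, with the structure `CC(=O)Oc1ccccc1C1CC(C)=NN1C(=O)CCl`, gives 2520 nM. Compound 3, with the structure `CNCC(=O)N1N=C(c2cc3ccccc3oc2=O)CC1c1ccccc1`, gives 24000 nM. Among these, compound 3 stands at the highest number of the three. Its nearest neighbour is compound 1, whose number lies within the usual scatter of compound 3, so the two cannot be told apart. Compound 2 is the furthest away, with a number well beyond the scatter below that of compound 3.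

Compound 4, with the structure `CC1CCCN(CC(=O)N2N=C(c3cc4ccccc4oc3=O)CC2c2ccccc2)C1`, has not yet been measured in this assay. It differs from compound 3 in one place: 3-methylpiperidin-1-yl in place of methylamino on a saturated chain carbon bound to a carbonyl carbon. Among the compounds with values here, no measured pair shows the effect of such a change, so the expectation rests on compound 3 alone. The step from compound 3 to compound 4 is expected to be a 1.3-fold lower number from compound 3 to compound 4 (0.12 log units; within the scatter), that is, no move beyond the scatter. Compound 4 is therefore estimated at 18000 nM, with a range from 6000 nM to 50000 nM.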

Compound 4, half-maximal inhibitory concentration: "not active" (no number reported)
Nothing numeric was reported for compound 4; there is nothing to compare the estimate with.
By their numbers in this assay, from the lowest: compound 2; then compounds 1 and 3 (each within the scatter of the next).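

Within the data shown here, compound 4 is reported as "not active" with no number, so no step from compound 3 to compound 4 can be read. Nothing shown offers an explanation for this result. The compounds shown leave open how far replacing methylamino with 3-methylpiperidin-1-yl moves the number.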